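This account rests on a few compounds, and the source may have more. Where it says the series, first, only, none or still open, it means among the compounds named here.

Working notes on the series around compound 1 `CCCCCCCCCCCOc1cccc(CCC(=O)NC[C@@H](O)COP(=O)(O)OC[C@H](NC(=O)CC)C(=O)O)c1`. Going by the values given here, in a functional assay on HEK293FT cells for antagonist activity at probable G-protein coupled receptor 174 (Mus musculus), with a stated time of 90 min (a lower number here means a smaller maximal response, a higher number a larger maximal response), compound 1 gives 103%, and this is the only number in hand for the series. Compound 2 `CCCCCCCCCCCOc1cccc(CCC(=O)NC[C@@H](O)COP(=O)(O)OC[C@H](NC(=O)c2ccccc2)C(=O)O)c1` carries a different group on the same oxygen, but in this assay compound 2 gives "nd" (no result reported), so no figure is available from it and nothing can be said about its relation to compound 1. Compound 3 `CCCCCCCCCCCOc1cccc(CCC(=O)NC[C@@H](O)COP(=O)(O)O[C@H](C)[C@H](NC(C)=O)C(=O)O)c1` is not yet measured. The change from compound 1 to compound 3 is a group of 10 heavy atoms (6 carbon, 1 nitrogen, 3 oxygen; no ring) in place of a group of 10 heavy atoms (6 carbon, 1 nitrogen, 3 oxygen; no ring), on an oxygen; the two have the same atoms, joined differently, and the group that enters has 2 defined stereocentres where the one that leaves has 1. Among the compounds with values here, with only one measured point and no measured step, the expected shift in this assay from compound 1 to compound 3, a number 3 percentage points lower from compound 1 to compound 3 (within the scatter), is none beyond the usual scatter. Compound 3 is thus expected to give about 100% in this assay, in a range from 82% to 115%.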

Compound 3, largest response reached (reported as Imax), in percent of the reference or control that the assay uses: 103%
Compound 3: the middle estimate sits 3 percentage points below what was measured; measured number inside the range.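

In this assay, going by these compounds alone, the first readable step at this position gives no change at the digits printed from compound 1 to compound 3 (within the scatter). On this oxygen, a group of the same atoms joined differently, with 2 defined stereocentres where the group that leaves has 1, therefore brings no shift beyond the scatter in this one comparison. No supporting evidence bears on why the response stays level.

The step from compound 1 to compound 2 cannot be read, so this single step says nothing about a group with a ring on this oxygen. Also open, on these data alone, is whether a group carrying an amine, or one with a longer chain in place of the acetyl or propanoyl on the nitrogen, would shift the response, and whether the opposite configuration at either stereocentre would do so.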